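The source may report more compounds than this note shows. Statements on the series, on what has been measured and on what is new or still open speak of the compounds shown alone.

Compound 1 `CCCCc1cnc(Cc2ccc(-c3ccccc3C(=O)O)cc2)[nH]1`: in an in vitro functional assay on cells for agonist activity at Bombesin receptor subtype-3 (Homo sapiens), read by luminescence and calcium flux (a higher number here means that more compound is needed for the effect, a lower number that less compound is needed), compound 1 reports > 10000 nM, which is a limit of the assay rather than a number.
Compound 2 `O=C(O)c1ccccc1-c1ccc(CCc2ncc(Cc3ccc(Cl)cc3)[nH]2)cc1`: in this assay compound 2 gives 2290 nM.
Compound 3 `CCCCc1cnc(C(CCCO)Cc2ccc(-c3ccccc3C(=O)O)cc2)[nH]1`: in this assay compound 3 gives 1900 nM.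
Compound 4 `N#Cc1ccccc1Cc1cnc(CCc2ccc(-c3ccccc3C(=O)O)cc2)[nH]1`: not yet measured.

Among the numbers shown, compound 2 and compound 3 lie within the usual scatter of each other, so neither can be called more or less potent than the other. Compound 1 gives only a limit. Compound 4 differs from compound 2 in one place: 2-cyanophenyl in place of 4-chlorophenyl on a saturated chain carbon bound to an aromatic carbon. Among the compounds with values here, no measured pair isolates this kind of change, so the size of the step in this assay is uncertain, and a shift beyond the scatter in either direction remains possible. The step expected is a 1.3-fold higher number from compound 2 to compound 4 (0.12 log units; within the scatter). Compound 4 is estimated at 3000 nM, with a range from 800 nM to 12000 nM.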

Compound 4, half-maximal effective concentration: 5480 nM
Beside the measured number, compound 4's estimate is 1.8-fold (0.26 log units) below it; low and high end bracket the measured number.
By their numbers in this assay, from the lowest: compounds 3 and 2 (each within the scatter of the next); then compound 4. At a limit, above all of these: compound 1.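

In this assay the change from 4-chlorophenyl to 2-cyanophenyl on a saturated chain carbon bound to an aromatic carbon gives a 2.4-fold higher number from compound 2 to compound 4 (0.38 log units; beyond the scatter) and so shows that this position responds to the group placed there, if only modestly. Both the substituent and its place on the ring change at once, and this single step cannot separate the two. Nothing measured here explains the step.
From the compounds shown here alone, it remains open whether 4-cyanophenyl or 2-chlorophenyl would track compound 2 or compound 4. An unsubstituted phenyl would show what either substituent contributes.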